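Chloroacetamide to acrylamide on a hydroxymethyl pyrazole scaffold

The compounds below may be only part of what the source reports. "The series", "measured", "known", "first", "only" and "open" are said of these compounds alone.

Compound 1 `O=C(CCl)Nc1ccc(Cn2nc(-c3ccc(Oc4ccccc4)cc3)cc2CO)cc1` gives the lowest number of the three measured in a functional assay on Maver1 cells (Homo sapiens) for inhibition, read by luminescence and CellTiter-Glo, with a stated time of 72 h (a higher number here means a weaker inhibitor, a lower number a stronger inhibitor), with 400 nM. Compound 3 `O=C(CCl)Nc1ccc(Cn2nc(-c3ccc(Oc4ccccc4)cc3)cc2C(=O)O)cc1` follows with 1200 nM, the step being a 3.0-fold higher number from compound 1 to compound 3 (0.48 log units; beyond the scatter). Compound 2 `C/C=C/C(=O)Nc1cccc(Cn2nc(-c3ccc(Oc4ccccc4)cc3)cc2C(=O)O)c1` gives 31600 nM; it differs from the others in several places, so only its value is shown. Compound 4 `C=CC(=O)Nc1ccc(Cn2nc(-c3ccc(Oc4ccccc4)cc3)cc2CO)cc1` keeps the hydroxymethyl group of compound 1 and changes the amide: vinyl in place of chloromethyl on a carbonyl carbon. No measured step isolates this change; the single step shown concerns the hydroxymethyl-to-carboxy exchange, not the amide. The expectation for compound 4 is therefore a modest rise, a 2.3-fold higher number from compound 1 to compound 4 (0.35 log units; beyond the scatter), with wide uncertainty. Compound 4 is estimated at 900 nM, in the range 200 nM to 4000 nM.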

Compound 4, half-maximal inhibitory concentration: 7000 nM
Beside the measured number, compound 4's estimate is 7.8-fold (0.89 log units) below it; the whole stated range lies below it.
By their numbers in this assay, from the lowest: compound 1; then compound 3; then compound 4; then compound 2.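

The amide side of the molecule turns out to be the more sensitive of the two places changed so far: vinyl in place of chloromethyl on a carbonyl carbon gives an 18-fold higher number from compound 1 to compound 4 (1.24 log units; beyond the scatter) in this assay, a large step where the exchange of hydroxymethyl for carboxy gave only a modest one, a 3.0-fold higher number from compound 1 to compound 3 (0.48 log units; beyond the scatter). Nothing available accounts for the size of this step.

From the compounds shown here alone, it remains open whether the same exchange costs as much when carboxy replaces hydroxymethyl. Going by these compounds, how a bromomethyl or a longer chain on that carbonyl carbon would read also remains open.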